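The source may hold more compounds than are shown below. What is called first, only, known or untested is meant among the compounds shown, and "the series" means these compounds.

Compound 2 `C[C@@H](CCCN1CCCC1)Nc1ccnc2cc(Cl)ccc12` gives 180000 nM in an assay for binding affinity, read by spectrophotometry (a lower number here means a stronger inhibitor, a higher number a weaker inhibitor), and stands level with compound 3 `C[C@H](CCCN1CCN(C)CC1)Nc1ccnc2cc(Cl)ccc12`, which gives 180000 nM; together these are the highest numbers of the three. Compound 1 `C[C@H](CCCN1CCCC1)Nc1ccnc2cc(Cl)ccc12` gives 140000 nM, and the step of a 1.3-fold higher number from compound 1 to compound 2 (0.11 log units; within the scatter) rests only on (the fact that compounds 1 and 2 differ only in the configuration as drawn). Within the data shown here, the one change of the terminal amine ring so far, a 1.3-fold higher number from compound 1 to compound 3 (0.11 log units; within the scatter), also stayed within the scatter. Compound 4 `C[C@@H](CCCN1CCCCC1)Nc1ccnc2cc(Cl)ccc12` differs from compound 2 by piperidin-1-yl in place of pyrrolidin-1-yl on a saturated chain carbon, four bonds along the chain from a nitrogen on an aromatic ring. Since ring enlargement at this position, compound 1 to compound 3, gave a 1.3-fold higher number from compound 1 to compound 3 (0.11 log units; within the scatter), the step is expected to stay within the scatter, no change at the digits printed from compound 2 to compound 4 (within the scatter). Compound 4 is therefore estimated at 180000 nM in this assay, with a range of 90000 nM to 360000 nM.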

Compound 4, half-maximal inhibitory concentration: 150000 nM
Compound 4: middle estimate off by 1.2-fold (0.08 log units), on the high side; measured number inside the range.
By their numbers in this assay, from the lowest: compounds 1, 4, 2 and 3 (each within the scatter of the next).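

The step to piperidin-1-yl gives a 1.2-fold lower number from compound 2 to compound 4 (0.08 log units; within the scatter). This extends the earlier result to a second ring at this chain position, now in the compound drawn S: in this assay, neither ring exchange tested so far leaves the scatter. Nothing available gives a cause for this step.

As far as these compounds go, whether any group at this position can move the number beyond the scatter remains open. A morpholin-4-yl ring, an open-chain diethylamino group or a longer chain would test this.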